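The compounds below may be only part of what the source reports. "The series", "measured", "known", "first", "only" and "open" are said of these compounds alone.

Of the compounds shown here, three built on a shared core have been measured in a functional assay on HeLa cells (Homo sapiens) for cytotoxicity, read by WST assay, with a stated time of 48 h; on this read-out lower numbers stand for stronger inhibition and higher numbers for weaker inhibition. Compound 1, `COc1ccc([C@H]2OC[C@H]([C@@H](O)c3ccc(OC)c(OC)c3)C[C@@H]2C/C=C/c2ccccc2)cc1OC`, gives 14800 nM. Compound 3, `COc1ccc(/C=C/C[C@H]2C[C@@H]([C@@H](O)c3ccccc3)CO[C@@H]2c2ccc(OC)c(OC)c2)cc1OC`, gives 15500 nM. Compound 2, `O[C@@H](c1ccccc1)[C@H]1CO[C@H](c2ccccc2)[C@@H](C/C=C/c2cccc(F)c2)C1`, gives 8380 nM, the lowest of the three numbers, yet its gaps to compound 1 and to compound 3 both lie within the usual scatter of repeated measurements, so the three cannot be told apart on these data. Compound 4, `O[C@@H](c1ccccc1)[C@H]1CO[C@H](c2ccccc2)[C@@H](C/C=C/c2ccccc2F)C1`, has not yet been measured. It is made of the same atoms as compound 2, joined differently: 2-fluorophenyl in place of 3-fluorophenyl on a double-bonded chain carbon bound to a double-bonded chain carbon. Within the data shown here, no pair of measured compounds differs in only one place, so no measured step shows how exchanging one fluorophenyl for the other acts on this read-out. With nothing in the measured values pointing either way, the expected step in this assay is a 1.0-fold higher number from compound 2 to compound 4 (0.01 log units; within the scatter), within the scatter and in no particular direction. Compound 4 is therefore estimated at 8500 nM in this assay, with a range from 3500 nM to 20000 nM.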

Compound 4, half-maximal inhibitory concentration: 9730 nM
Estimate against measurement, compound 4: 1.1-fold (0.06 log units) below, within the range that was stated.
By their numbers in this assay, from the lowest: compounds 2, 4, 1 and 3 (each within the scatter of the next).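

In this assay, among these compounds, putting 2-fluorophenyl in place of 3-fluorophenyl on a double-bonded chain carbon bound to a double-bonded chain carbon gives a 1.2-fold higher number from compound 2 to compound 4 (0.06 log units; within the scatter) and is the first comparison in this set that changes only one place. This step lies within the scatter, so at this place the read-out does not tell the two fluorophenyl groups apart. The data offer no separate measurement that could explain this result.

Going by these compounds, it remains open whether a larger change on this ring, such as an amine or a carboxylic acid in place of the fluorine, or a longer chain linking the ring to the shared core, would move the number beyond the scatter. Also open, on these data alone, is whether the exchange of one fluorophenyl for the other would read the same way with the other rings of compound 2 changed.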